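A second ester on compound 3

The compounds below may be only part of what the source reports. "The series", "measured", "known", "first", "only" and "open" are said of these compounds alone.

- compound 1 `CC(=O)Oc1ccc(/C=C/C(=O)O[C@@H]2C=C[C@@]3(C[C@H]2OC(=O)/C=C/c2ccc(OC(C)=O)c(OC(C)=O)c2)OC(C)(C)OC3=O)cc1OC(C)=O` gives 6.3 ug/mL
- compound 2 `O=C(/C=C/c1ccc(O)c(O)c1)O[C@@H]1C[C@](O)(C(=O)O)C=C[C@H]1O` gives 0.5 ug/mL
- compound 3 `O=C(/C=C/c1ccc(O)c(O)c1)O[C@@H]1C=C[C@@](O)(C(=O)O)C[C@H]1O` gives 0.7 ug/mL

In a functional assay, read by WST assay (a lower number here means a stronger inhibitor, a higher number a weaker inhibitor), compound 3 lies within the scatter of compound 2 and well under compound 1. Compound 4 `O=C(/C=C/c1ccc(O)c(O)c1)O[C@@H]1C=C[C@@](O)(C(=O)O)C[C@H]1OC(=O)/C=C/c1ccc(O)c(O)c1` follows from compound 3 by one change: (2-(3,4-dihydroxyphenyl)ethenyl)carbonyl in place of hydrogen on an oxygen on a saturated carbon This places (2-(3,4-dihydroxyphenyl)ethenyl)carbonyl in place of hydrogen on an oxygen on a saturated carbon. Going by the values given here, no measured pair isolates this change. Compound 1 carries this kind of ester in acetylated form, but it differs from compound 3 in other places too, so it cannot fix the size of the step. A shift beyond the scatter is therefore not expected, and the estimated step is a 1.2-fold lower number from compound 3 to compound 4 (0.07 log units; within the scatter) in size. Compound 4 is estimated at 0.6 ug/mL with 0.2 ug/mL to 2.5 ug/mL as its expected range.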

Compound 4, half-maximal inhibitory concentration: 1.9 ug/mL
Compound 4: the middle estimate sits 3.2-fold (0.50 log units) below what was measured, and the stated range covers the measured number.
By their numbers in this assay, from the lowest: compounds 2 and 3 (each within the scatter of the next); then compound 4; then compound 1.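

In this assay, the (2-(3,4-dihydroxyphenyl)ethenyl)carbonyl group on this oxygen on a saturated carbon gives a 2.7-fold higher number from compound 3 to compound 4 (0.43 log units; beyond the scatter), so this position tolerates the second ester, though the number rises modestly. The comparison with the other monoester shows the same direction, with a 3.8-fold higher number from compound 2 to compound 4 (0.58 log units; beyond the scatter). Nothing available gives a reason for this rise. The compounds shown leave open whether a smaller group on this oxygen, such as acetyl or methyl, would also raise the number. They also leave open whether a longer chain would raise it further.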